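Swapping the aryl group on a quinazoline amine nitrogen

The source may hold more compounds than are shown below. What is called first, only, known or untested is meant among the compounds shown, and "the series" means these compounds.

Of the compounds shown here, three sharing one core have been tested in a functional assay on PC-3 cells (Homo sapiens) for cytotoxicity, read by MTT assay, with a stated time of 72 h; a lower number here means a stronger inhibitor, a higher number a weaker inhibitor. Compound 1 `CCCCCCNc1nc(SCc2ccc(C(F)(F)F)cc2)nc2ccccc12` gives 19000 nM. Compound 2 `FC(F)(F)c1ccc(CSc2nc(Nc3ccccc3Cl)c3ccccc3n2)cc1` gives 20400 nM. Compound 3 `Cc1ccccc1Nc1nc(SCc2ccc(C(F)(F)F)cc2)nc2ccccc12` gives 36900 nM, the highest number of the three, yet its gaps to compound 2 and compound 1 both fall within the usual scatter, so no ordering among them can be claimed. The steps recorded so far all touch the same position: a 1.1-fold higher number from compound 1 to compound 2 (0.03 log units; within the scatter), a 1.9-fold higher number from compound 1 to compound 3 (0.29 log units; within the scatter) and a 1.8-fold higher number from compound 2 to compound 3 (0.26 log units; within the scatter), each within the scatter.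

Compound 4 `COc1ccc(Nc2nc(SCc3ccc(C(F)(F)F)cc3)nc3ccccc23)cc1` has not yet been measured. It differs from compound 3 by 4-methoxyphenyl in place of 2-methylphenyl on a nitrogen on an aromatic ring. Both earlier changes at this nitrogen, whether a hexyl chain replaced by a 2-chlorophenyl or a 2-methylphenyl, or a chloro replaced by a methyl on that ring, left the number in this assay essentially unmoved. Within the data shown here, no step shows what a methoxy at this position does, so the expectation rests on the three compounds alone, and the expected step from compound 3 is a 1.3-fold lower number from compound 3 to compound 4 (0.12 log units; within the scatter), no more than the scatter. Compound 4 is therefore estimated at 28000 nM, with a range from 11000 nM to 70000 nM.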

Compound 4, half-maximal inhibitory concentration: 16700 nM
Compound 4: middle estimate off by 1.7-fold (0.22 log units), on the high side, and the stated range covers the measured number.
By their numbers in this assay, from the lowest: compounds 4, 1, 2 and 3 (each within the scatter of the next, the first and the last beyond it).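

In this assay, among these compounds, the swap of 2-methylphenyl for 4-methoxyphenyl on this nitrogen gives the first single change here that lies beyond the scatter, a 2.2-fold lower number from compound 3 to compound 4 (0.34 log units; beyond the scatter), so the group at this position can move the number, though only modestly. That shift does not extend to the other groups: replacing 2-chlorophenyl with 4-methoxyphenyl gives a 1.2-fold lower number from compound 2 to compound 4 (0.09 log units; within the scatter), and replacing hexyl with 4-methoxyphenyl gives a 1.1-fold lower number from compound 1 to compound 4 (0.06 log units; within the scatter), so neither of those two swaps can be told apart from no change at all. Among the compounds shown here, nothing measured here explains why the one step stands out.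

The change from 2-methylphenyl to 4-methoxyphenyl alters both the substituent and where it sits on the ring, so these compounds cannot show which of the two matters. They also leave open what a plain phenyl with no substituent, a phenyl carrying an amine or a carboxylic acid, or a chain longer than hexyl would do on this nitrogen.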